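Fluoro gives way to chloro in compound 3

This account rests on a few compounds, and the source may have more. Where it says the series, first, only, none or still open, it means among the compounds named here.

Measured in a functional assay (aorta) for inhibition, with Rattus norvegicus as the target; on this read-out higher numbers stand for an effect only at larger amounts of compound and lower numbers for an effect already at smaller amounts:
compound 1 `O=C1C=C(Nc2ccccc2)C(=O)c2cnccc21`: 439 nM
compound 2 `O=C1C=C(Nc2ccc(F)cc2)C(=O)c2cnccc21`: 1230 nM

Of these two, compound 2 has the higher number, at 1230 nM. Compound 3 `O=C1C=C(Nc2ccc(Cl)cc2)C(=O)c2cnccc21` differs from it in one place: chloro in place of fluoro on an aromatic carbon, para to a large group. Going by the values given here, only one measured step bears on this, the modest 2.8-fold higher number from compound 1 to compound 2 (0.45 log units; beyond the scatter), which put fluoro in place of hydrogen on that carbon. Among the compounds with values here, no measured step exchanges one halogen for another, so in this assay no change beyond the scatter is expected. The expected step is a 1.2-fold lower number from compound 2 to compound 3 (0.09 log units; within the scatter). Compound 3 is estimated at 1000 nM, with an expected range of 350 nM to 2900 nM.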

Compound 3, half-maximal effective concentration: 190 nM
The estimate for compound 3 lay 5.3-fold (0.72 log units) above the measured number; the measured number lies below the stated range.
By their numbers in this assay, from the lowest: compound 3; then compound 1; then compound 2.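

In this assay, this position turns out not to treat the two halogens alike: chloro in place of fluoro gives a far larger change (a 6.5-fold lower number from compound 2 to compound 3 (0.81 log units; beyond the scatter)) than the first step suggested. Set against hydrogen, chloro also moves the number the opposite way to fluoro (chloro: a 2.3-fold lower number from compound 1 to compound 3 (0.36 log units; beyond the scatter); fluoro: a 2.8-fold higher number from compound 1 to compound 2 (0.45 log units; beyond the scatter)), so a substituent on this carbon can shift it in either direction.

From the compounds shown here alone, whether bromo, methyl or methoxy on this carbon would give a still lower number remains open. Nothing available explains why chloro and fluoro part ways here.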